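Sulfonamide variation on a pyrrolo-lactam acid series

This account rests on a few compounds, and the source may have more. Where it says the series, first, only, none or still open, it means among the compounds named here.

Two analogues of the shared core have been run in a functional assay on CHO.K1 cells for antagonist activity at prostaglandin D2 receptor 2 (Homo sapiens), read by GTPgammaS binding, with a stated time of 1 h; on this read-out higher numbers stand for weaker inhibition and lower numbers for stronger inhibition. Compound 1 `Cc1c(Cc2ccccc2S(=O)(=O)C2CCCCC2)c2c(n1CC(=O)O)CCNC2=O` carries a cyclohexyl on the sulfonyl sulfur and in this assay compound 1 gives 28 nM. Compound 2 `Cc1c(Cc2ccccc2S(=O)(=O)N2CCOCC2)c2c(n1CC(=O)O)CCNC2=O` carries a morpholin-4-yl on that sulfur, and in this assay compound 2 gives 22 nM. Among the compounds with values here, the only recorded step is a 1.3-fold lower number from compound 1 to compound 2 (0.10 log units; within the scatter), so compound 2 stands nearest compound 1 among the two numbers, with the gap between them inside the scatter.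

Compound 3 `Cc1c(Cc2ccccc2S(=O)(=O)N(C)Cc2ccccc2)c2c(n1CC(=O)O)CCNC2=O` is not yet measured. Its difference from compound 2 is benzyl(methyl)amino in place of morpholin-4-yl on a sulfonyl sulfur. Within the data shown here, the one step that bears on this position, from compound 1 to compound 2, exchanged one saturated six-membered substituent for another on the sulfonyl sulfur and stayed within the scatter; no measured step introduces an aromatic ring at this site. On that basis the expected step of a 1.4-fold higher number from compound 2 to compound 3 (0.13 log units; within the scatter) is none beyond the scatter, with the range widened for the untested benzyl(methyl)amino. Compound 3 is therefore estimated at 30 nM in this assay, between 10 nM and 90 nM.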

Compound 3, half-maximal inhibitory concentration: 26 nM
The estimate for compound 3 lay 1.2-fold (0.06 log units) above the measured number, and the stated range covers the measured number.
By their numbers in this assay, from the lowest: compounds 2, 3 and 1 (each within the scatter of the next).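

Notes on the sulfonyl site: in this assay, benzyl(methyl)amino brings an aromatic ring of carbon only to the sulfonyl sulfur, a feature absent from both earlier substituents, and the step stays within the scatter (a 1.2-fold higher number from compound 2 to compound 3 (0.07 log units; within the scatter)). The comparison with the carbon-linked cyclohexyl also stays within the scatter (a 1.1-fold lower number from compound 1 to compound 3 (0.03 log units; within the scatter)), so cyclohexyl, morpholin-4-yl and benzyl(methyl)amino cannot be told apart on this read-out, even though the last has no hydrogen-bond acceptor and more heavy atoms than morpholin-4-yl. No supporting data are available to explain why these numbers stay together.

The three substituents shown do not establish whether this site would remain as undemanding with a group able to carry charge, such as a piperazin-1-yl with a free amine or a benzyl bearing a carboxylic acid. Also open, as far as these compounds go, is whether a sulfonamide that retains a nitrogen-bound hydrogen, or a much smaller group such as dimethylamino, would stay within the scatter of these three compounds.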